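The compounds below may be only part of what the source reports. "The series", "measured", "known", "first", "only" and "open" are said of these compounds alone.

Compound 1 `CCCN(CC[C@H]1CC[C@H](NC(=O)/C=C/c2ccc(F)cc2)CC1)[C@H]1CCc2nc(N)sc2C1` gives 1 nM in an assay on brain for displacement of a labelled ligand from D(3) dopamine receptor (Rattus norvegicus); a lower number here means a stronger inhibitor, a higher number a weaker inhibitor.
Compound 2 `CCCN(CC[C@H]1CC[C@H](NC(=O)/C=C/c2ccccc2OC)CC1)[C@H]1CCc2nc(N)sc2C1` gives 8.1 nM in this assay.
Compound 3 `CCCN(CC[C@H]1CC[C@H](NC(=O)c2cccc(-n3ccnc3)c2)CC1)[C@H]1CCc2nc(N)sc2C1` gives 1.1 nM in this assay.

Among these three numbers compound 3 holds the second highest place. Its nearest neighbour is compound 1, and the step of a 1.1-fold higher number from compound 1 to compound 3 (0.04 log units; within the scatter) lies within the usual scatter, so the two cannot be told apart. Its furthest neighbour is compound 2, and the step of a 7.4-fold lower number from compound 2 to compound 3 (0.87 log units; beyond the scatter) is modest but clearly beyond the scatter.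

Compound 4 `CCCN(CC[C@H]1CC[C@H](NC(=O)c2ccc(-n3cccn3)cc2)CC1)[C@H]1CCc2nc(N)sc2C1` keeps the shared core of compound 3 and differs only in the group on the carbonyl carbon: 4-(1H-pyrazol-1-yl)phenyl in place of 3-(1H-imidazol-1-yl)phenyl on a carbonyl carbon. The same atoms are present in both, joined differently.

Going by the values given here, no measured step swaps one such group for another in exactly this way. The closest guide is an 8.1-fold higher number from compound 1 to compound 2 (0.91 log units; beyond the scatter), where a change in the pattern on an aromatic ring attached to the carbonyl side produced a modest shift. The swap a 1.1-fold higher number from compound 1 to compound 3 (0.04 log units; within the scatter) shows that quite different groups on the carbonyl carbon can give the same number. Taken together, a modest change at most is expected, most likely a somewhat higher number, a 2.3-fold higher number from compound 3 to compound 4 (0.36 log units; beyond the scatter).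

Compound 4 is therefore estimated at 2.5 nM in this assay, with a range from 0.7 nM to 10 nM.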

Compound 4, inhibition constant: 3 nM
Compound 4: the middle estimate sits 1.2-fold (0.08 log units) below what was measured, within the range that was stated.
By their numbers in this assay, from the lowest: compounds 1 and 3 (each within the scatter of the next); then compound 4; then compound 2.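

The two groups on the carbonyl carbon have the same heavy atoms, the same kinds of ring and the same hydrogen-bond counts, yet in this assay joining those atoms differently gives a 2.7-fold higher number from compound 3 to compound 4 (0.44 log units; beyond the scatter), so this position registers how the atoms are arranged and not only which atoms are present. Compound 1 and compound 3 carry very different groups here and cannot be told apart, whereas this much closer pair can, and compound 4 stands apart from both ends of the series, with a 3.0-fold higher number from compound 1 to compound 4 (0.48 log units; beyond the scatter) and a 2.7-fold lower number from compound 2 to compound 4 (0.43 log units; beyond the scatter). Nothing measured on these compounds accounts for the shift.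

Two things differ at once between these groups, the name of the five-membered ring and the number giving its place on the phenyl, so the compounds shown cannot say which of them carries the step. From the compounds shown here alone, a compound bearing 3-(1H-pyrazol-1-yl)phenyl or 4-(1H-imidazol-1-yl)phenyl on the carbonyl carbon would separate the two, and how either group would read in this assay remains open.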